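The source may hold more compounds than are shown below. What is called first, only, known or untested is meant among the compounds shown, and "the series" means these compounds.

Measured compounds: compound 1 `CCOC(=O)CCC(=O)N1CCN(CCCOc2cc3c(Nc4ccc(F)c(Cl)c4)ncnc3cc2OC)CC1` at 70%; compound 2 `CCCOC(=O)CCC(=O)N1CCN(CCCOc2cc3c(Nc4ccc(F)c(Cl)c4)ncnc3cc2OC)CC1` at 87%; compound 3 `CCCCCCOC(=O)CCC(=O)N1CCN(CCCOc2cc3c(Nc4ccc(F)c(Cl)c4)ncnc3cc2OC)CC1` at 85.1%.

In a functional assay on A549 cells (Homo sapiens) for cytotoxicity, read by MTT assay, with a stated time of 24 h, tested at 20 uM (a lower number here means a stronger effect, a higher number a weaker effect of the compound at the concentration tested), compound 1 gives 70%. The change methyl in place of hydrogen on a saturated chain carbon, two bonds along the chain from an oxygen next to a carbonyl group produced a number 17 percentage points higher from compound 1 to compound 2 (beyond the scatter). Compound 4 `CCCCCCCOC(=O)CCC(=O)N1CCN(CCCOc2cc3c(Nc4ccc(F)c(Cl)c4)ncnc3cc2OC)CC1` has not been measured; it differs from compound 3 by methyl in place of hydrogen on a saturated chain carbon, six bonds along the chain from an oxygen next to a carbonyl group. This is the same kind of change as that from compound 1 to compound 2, not the same change: there the methyl enters two bonds along the chain from an oxygen next to a carbonyl group, here six bonds along the chain from an oxygen next to a carbonyl group. The cores of compound 1 and compound 3 differ by butyl in place of hydrogen on a saturated chain carbon, two bonds along the chain from an oxygen next to a carbonyl group, which gave a number 15.1 percentage points higher from compound 1 to compound 3 (beyond the scatter); the longer chain of compound 3 gave a number 1.9 percentage points lower from compound 2 to compound 3 (within the scatter). Because a number 1.9 percentage points lower from compound 2 to compound 3 (within the scatter) lies within the scatter, compound 4 is expected to stay close to compound 3, with an expected step of a number 0.9 percentage points higher from compound 3 to compound 4 (within the scatter). The estimate for compound 4 is 86%, expected between 72% and 98%.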

Compound 4, a percentage reported as activity, at one concentration (the size of the read-out at that concentration, not a potency): 79.9%
The estimate for compound 4 lay 6.1 percentage points above the measured number, and the stated range covers the measured number.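

In this assay, adding a methyl did not carry over from one core to another: the same change on two cores in this assay, a number 17 percentage points higher (beyond the scatter) from compound 1 to compound 2 and a number 5.2 percentage points lower (within the scatter) from compound 3 to compound 4, 22.2 percentage points apart, beyond the scatter of two such steps. The butyl change did not carry over either: the same change on two cores in this assay, a number 15.1 percentage points higher (beyond the scatter) from compound 1 to compound 3 and a number 7.1 percentage points lower (within the scatter) from compound 2 to compound 4, 22.2 percentage points apart, beyond the scatter of two such steps. Among the compounds shown here, with a number 5.2 percentage points lower from compound 3 to compound 4 (within the scatter), a number 7.1 percentage points lower from compound 2 to compound 4 (within the scatter) and a number 9.9 percentage points higher from compound 1 to compound 4 (within the scatter), compound 4 cannot be told apart from any of the other three compounds, and the two comparisons show only that the step differs with the core in these esters, not why it differs or how it would behave on other cores.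

The compounds shown leave open how a branched chain, a longer chain or a phenyl ring in the ester would read. They also leave open what a carboxylic acid or an amine in place of the ester would give.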